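Cytotoxicity at the Limit: Aryl Carbonyl Variation on a Sulfonamide Core

The source may report more compounds than this note shows. Statements on the series, on what has been measured and on what is new or still open speak of the compounds shown alone.

Compound 1, with the structure `Cc1ccc(S(=O)(=O)N[C@@H](CC(=O)NC(C)(C)C)C(=O)NCCNC(=O)Nc2ccccc2)cc1`, was tested in an ADME assay on Karpas-1106P cells (Homo sapiens) for cytotoxicity; on this read-out higher numbers stand for an effect only at larger amounts of compound and lower numbers for an effect already at smaller amounts. In this assay compound 1 gives > 11100 nM, which is a limit of the assay rather than a number. Compound 2, with the structure `COc1cccc(C(=O)NCCNC(=O)[C@H](CC(=O)NC(C)(C)C)NS(=O)(=O)c2ccc(C)cc2)c1`, carries a 3-methoxyphenyl in place of anilino on a carbonyl carbon. In this assay compound 2 gives > 11100 nM, again a limit. The step that the two limits leave unreadable from compound 1 to compound 2 therefore cannot be read in size or direction. Going by the values given here, the one piece of evidence is the limit of > 11100 nM in this assay, at which 2 of the 2 values shown sit, which shows that both measured compounds sit at the limit.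

Compound 3, with the structure `Cc1ccc(S(=O)(=O)N[C@@H](CC(=O)NC(C)(C)C)C(=O)NCCNC(=O)c2ccc(Cl)cc2)cc1`, differs from compound 1 by 4-chlorophenyl in place of anilino on a carbonyl carbon. Among the compounds with values here, the only step measured so far is the unreadable one from compound 1 to compound 2, so there is no measured guide to how large this change should be. Given that compound 1 sits at the limit, compound 3 is expected to show no effect within the measured range either, and the estimated step that the limit leaves unreadable from compound 1 to compound 3 is expected to be none beyond the scatter. Compound 3 is therefore estimated at 15000 nM, with a range from 7000 nM to 40000 nM.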

Compound 3, half-maximal effective concentration: > 11100 nM
Compound 3 gave a limit, no number; the forecaster's own chance of this, stated with the estimate: 75%; the middle value is on the limit's open side.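

In this assay compound 3 also gives a limit and not a number, so the steps linking compound 1, compound 2 and compound 3 cannot be read in size or direction: the limit of > 11100 nM in this assay, at which 3 of the 3 values shown sit. The compounds shown leave open whether any group on this carbonyl carbon brings cytotoxicity into the measurable range, and how the three compounds would rank.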